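The source may hold more compounds than are shown below. What is called first, only, known or untested is meant among the compounds shown, and "the series" means these compounds.

Measured in a functional assay on A549 cells (Homo sapiens) for cytotoxicity, read by MTT assay, with a stated time of 72 h; on this read-out lower numbers stand for an effect already at smaller amounts and higher numbers for an effect only at larger amounts of compound:
Compound 1 `CCOc1c(-c2occ(C)c2C(=O)O)ccc2c(CC)cccc12`: > 10 ug/mL (a limit)
Compound 2 `CCOC(=O)c1c(C)coc1-c1ccc2c(CC)cccc2c1OC`: 3.8 ug/mL
Compound 3 `CCCOC(=O)c1c(C)coc1-c1ccc2c(CC)cccc2c1OC`: > 10 ug/mL (a limit)

Compound 3 has no number on this scale, only a limit. It stands with compound 1 at the limit of > 10 ug/mL in this assay, at which 2 of the 3 values shown sit. The next compound, compound 4 `CCc1cccc2c(OC)c(-c3occ(C)c3C(=O)NC)ccc12`, differs from compound 3 as follows: methylamino in place of propoxy on a carbonyl carbon. In words, it carries methylamino in place of propoxy on a carbonyl carbon.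

For the measured compounds named here, one measured step bears on this, an at least 2.6-fold higher number from compound 2 to compound 3 (0.42 log units; beyond the scatter). It lies beyond the scatter and falls on the group that now leaves, so the number in this assay can respond to changes there. Going by the values given here, no measured compound carries methylamino on this carbonyl carbon, so the size of the new change is not known from the data. Compound 2, at 3.8 ug/mL, shows a number that a compound of this set can reach, and a lower number for compound 4 is therefore possible. A reading at the limit is about as likely. As far as these compounds go, the expected a number no higher from compound 3 to compound 4 (the limit leaves the size open) is therefore no clear step beyond the scatter, and its direction stays open. For compound 4 the estimated value is 10 ug/mL, with an expected range from 4 ug/mL to 25 ug/mL.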

Compound 4, concentration for half-maximal effect: > 10 ug/mL
Compound 4: only a limit was reported; the forecaster's own chance of this, stated with the estimate: 55%; the middle value sits exactly at the limit.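

In this assay, swapping the ethoxy group on the carbonyl carbon for methylamino gives an at least 2.6-fold higher number from compound 2 to compound 4 (0.42 log units; beyond the scatter). The number at this carbonyl carbon therefore moves away from that of compound 2 not only with the longer propoxy chain, but also when an amide nitrogen takes the place of the ester oxygen, so compound 2 now stands alone among the esters and the amide shown. The step between the propoxy and methylamino compounds cannot be read, as both compounds carry only a limit, and compound 2 remains the only one with a number on this scale: the limit of > 10 ug/mL in this assay, at which 3 of the 4 values shown sit.

As far as these compounds go, how far compound 3 and compound 4 lie past that limit remains open, so the data do not rank propoxy against methylamino at this carbon. Also open, from the compounds shown here alone, is whether a methyl ester, an unsubstituted amide or a dimethylamide on the same carbonyl carbon would give a number on this scale, and so whether ethoxy is a narrow requirement or one of several groups tolerated there.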